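A few compounds are considered here, and "the series" means these few. Any claim that something is new, unique, unknown or untested is made for them only; others in the source may bear on it.

In a functional assay for inhibition of Polyunsaturated fatty acid 5-lipoxygenase (Homo sapiens) (on this read-out higher numbers stand for weaker inhibition and lower numbers for stronger inhibition), compound 2 `O=C(O)/C(CSCCO)=N/OC(c1ccc(OCc2ccc3ccccc3n2)cc1)C1CCCCC1` gives 181 nM, the highest number among the three measured compounds: compound 1 `CC/C(=N\OC(c1ccc(OCc2ccc3ccccc3n2)cc1)C1CCCCC1)C(=O)O` gives 30 nM and compound 3 `O=C(O)/C(CCc1ccccc1)=N/OC(c1ccc(OCc2ccc3ccccc3n2)cc1)C1CCCCC1` gives 20 nM. Compound 4 `C/C(CCCC(=O)O)=N\OC(c1ccc(OCc2ccc3ccccc3n2)cc1)C1CCCCC1` differs from compound 2 in that (a group of 9 heavy atoms (6 carbon, 1 nitrogen, 2 oxygen; no ring) in place of a group of 10 heavy atoms (5 carbon, 1 nitrogen, 3 oxygen, 1 sulfur; no ring), on an oxygen on a saturated carbon). Within the data shown here, two measured steps bear on this change, both leaving the (2-hydroxyethyl)sulfanyl group behind: a 6.0-fold higher number from compound 1 to compound 2 (0.78 log units; beyond the scatter) read in reverse, and a 9.1-fold lower number from compound 2 to compound 3 (0.96 log units; beyond the scatter). By contrast the step of a 1.5-fold lower number from compound 1 to compound 3 (0.18 log units; within the scatter) stayed within the scatter. Among the measured compounds shown here, since removing that group lowered the number both times, while the acid arm of compound 4 is rearranged in a way no measured step covers, a moderate lowering is expected for compound 4, a step of a 2.6-fold lower number from compound 2 to compound 4 (0.41 log units; beyond the scatter). Compound 4 is thus estimated at 70 nM, ranging from 20 nM to 300 nM.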

Compound 4, half-maximal inhibitory concentration: 59 nM
The estimate for compound 4 lay 1.2-fold (0.07 log units) above the measured number; low and high end bracket the measured number.
By their numbers in this assay, from the lowest: compounds 3, 1 and 4 (each within the scatter of the next, the first and the last beyond it); then compound 2.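

In this assay the group on this oxygen can lose the (2-hydroxyethyl)sulfanyl group and take a quite different arrangement of its carboxylic acid, and the result is a 3.1-fold lower number from compound 2 to compound 4 (0.49 log units; beyond the scatter). The further comparison, a 2.0-fold higher number from compound 1 to compound 4 (0.29 log units; within the scatter), stays within the scatter, so this position tolerates that rearrangement about as well as the simpler group of compound 1. Nothing available here gives a reason for either step. As far as these compounds go, whether a longer chain carrying the carboxylic acid, or an amide in its place, would keep this level remains open.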